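A few compounds are considered here, and "the series" means these few. Any claim that something is new, unique, unknown or untested is made for them only; others in the source may bear on it.

In an ADME assay on HEK293 cells (Homo sapiens) for cytotoxicity, read by MTT assay, with a stated time of 68 h (a lower number here means a stronger inhibitor, a higher number a weaker inhibitor), two compounds that share a core have been measured so far. Compound 1 `O=C(/C=C/c1cccc(OCc2ccccc2)c1)c1ccc(Cl)cc1`, with a chloro group on an aromatic carbon, gives 22800 nM, while compound 2 `Cc1ccc(C(=O)/C=C/c2cccc(OCc3ccccc3)c2)cc1`, with a methyl there instead, gives 8200 nM. Compound 2 thus holds the lower of the two numbers. Among the compounds with values here, the one measured step, a 2.8-fold lower number from compound 1 to compound 2 (0.44 log units; beyond the scatter), is modest but beyond the scatter.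

Compound 3 `COc1ccc(C(=O)/C=C/c2cccc(OCc3ccccc3)c2)cc1` takes the next step, with methoxy in place of methyl on an aromatic carbon, para to a large group: methoxy in place of methyl on an aromatic carbon. Within the data shown here, only the step to compound 2, a 2.8-fold lower number from compound 1 to compound 2 (0.44 log units; beyond the scatter), bears on this change, and no measured compound carries a methoxy group, so the guidance is thin. A change no larger than that modest step is expected, leaning slightly towards a higher number and possibly staying within the scatter. The expected change is a 1.3-fold higher number from compound 2 to compound 3 (0.13 log units; within the scatter). In this assay, compound 3 is expected at 11000 nM, with an estimated range of 4500 nM to 25000 nM.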

Compound 3, half-maximal inhibitory concentration: 79800 nM
Compound 3: middle estimate off by 7.3-fold (0.86 log units), on the low side, and the stated range ends below it.
By their numbers in this assay, from the lowest: compound 2; then compound 1; then compound 3.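

In this assay the position para to a large group proves far more sensitive to its substituent than the first step suggested: methoxy in place of methyl gives a 9.7-fold higher number from compound 2 to compound 3 (0.99 log units; beyond the scatter) and this exceeds the earlier move from chloro to methyl, which was a 2.8-fold lower number from compound 1 to compound 2 (0.44 log units; beyond the scatter) in the opposite direction. Methoxy also compares unfavourably with chloro, with a 3.5-fold higher number from compound 1 to compound 3 (0.54 log units; beyond the scatter) as the listed step, so the three groups at this one position rank methyl, chloro, methoxy from the lowest number to the highest, and compound 3 stands apart from both of the other compounds. No measurement available here offers an explanation for this order.

The compounds shown leave open whether the sharp rise follows the oxygen on the aromatic carbon or the longer group as a whole, which a hydroxy group, an ethoxy group or an amine at the same place would help to separate. They also leave open whether the same order among these groups would hold with a change elsewhere on the shared core.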